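Amide substituent variation in a phosphatase inhibitor series

The compounds below may be only part of what the source reports. "The series", "measured", "known", "first", "only" and "open" are said of these compounds alone.

Compound 1 `Cc1ccc(O)c(C(O)(C(F)(F)F)C(F)(F)F)c1` gives 207000 nM in an assay on isolated protein for inhibition of receptor-type tyrosine-protein phosphatase C (Homo sapiens), read by spectrophotometry; a lower number here means a stronger inhibitor, a higher number a weaker inhibitor. Compound 2 `CCCNC(=O)COc1ccc2cc(C(O)(C(F)(F)F)C(F)(F)F)c(O)cc2c1` stands at > 20000 nM in this assay, which is a limit of the assay and not a number. That ceiling, (the limit of > 20000 nM in this assay, at which 1 of the 2 values shown sits), is where compound 2 sits. Compound 3 `O=C(COc1ccc2cc(C(O)(C(F)(F)F)C(F)(F)F)c(O)cc2c1)NCc1ccccc1` differs from compound 2 by phenyl in place of ethyl on a saturated chain carbon bound to an amide-type nitrogen. Within the data shown here, no measured step of this kind exists, so the expected size rests on the change alone: a modest step toward stronger inhibition is expected, a step that the limit leaves unreadable from compound 2 to compound 3, with a real chance that only a limit is again reported. The estimate for compound 3 is 30000 nM, between 8000 nM and 100000 nM.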

Compound 3, half-maximal inhibitory concentration: > 20000 nM
Compound 3 ended at the assay's limit; the forecaster's own chance of this, stated with the estimate: 60%; the middle value lies beyond the limit too.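

Among these compounds, compound 2 and compound 3 both give only a limit of the assay in this assay, and no step between them can be read. On these data alone, whether phenyl in place of ethyl shifts inhibition at all remains open.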